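The source may hold more compounds than are shown below. What is called first, only, known or untested is meant among the compounds shown, and "the series" means these compounds.

Working notes on the series.

Compound 1 `COC(=O)c1ccc(CN(CCCc2c(N)nc(N)nc2O)c2cc(F)c([N+](=O)[O-])cc2[N+](=O)[O-])cc1` gives 3900 nM in a functional assay on CCRF-CEM cells (Homo sapiens) for cytotoxicity, in the absence of a further agent; a lower number here means a stronger inhibitor, a higher number a weaker inhibitor. Compound 3 `Nc1nc(N)c(CCCNc2cc(F)c([N+](=O)[O-])cc2[N+](=O)[O-])c(O)n1` gives 1100 nM in this assay; the step of a 3.5-fold lower number from compound 1 to compound 3 (0.55 log units; beyond the scatter) comes with the change (hydrogen in place of 4-(methoxycarbonyl)benzyl on a nitrogen on an aromatic ring). Compound 2 `COC(=O)c1ccc(CN(CCCc2c(N)nc(N)nc2O)c2ccc([N+](=O)[O-])c(F)c2F)cc1` gives 45000 nM in this assay, the highest number of the three measured; the difference between its core and the core of compound 1 is not broken down here. Compound 4 `Nc1nc(N)c(CCCNc2ccc([N+](=O)[O-])c(F)c2F)c(O)n1` is not yet measured; it relates to compound 2 by the change (hydrogen in place of 4-(methoxycarbonyl)benzyl on a nitrogen on an aromatic ring), the same change as that from compound 1 to compound 3, made at the same place. For compound 4 a step of about a 3.5-fold lower number from compound 2 to compound 4 (0.54 log units; beyond the scatter) is expected in this assay, beside the earlier one, resting on the step of a 3.5-fold lower number from compound 1 to compound 3 (0.55 log units; beyond the scatter) seen for compound 3. The estimate for compound 4 in this assay is 13000 nM, expected between 5000 nM and 35000 nM.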

Compound 4, half-maximal inhibitory concentration: 68000 nM
Estimate against measurement, compound 4: 5.2-fold (0.72 log units) below, and the stated range ends below it.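

In this assay, hydrogen in place of 4-(methoxycarbonyl)benzyl gives a 1.5-fold higher number from compound 2 to compound 4 (0.18 log units; within the scatter), so the change does not carry over as a fixed step between these two cores: the same change on two cores in this assay, a 3.5-fold lower number (0.55 log units; beyond the scatter) from compound 1 to compound 3 and a 1.5-fold higher number (0.18 log units; within the scatter) from compound 2 to compound 4, 5.4-fold (0.73 log units) apart, beyond the scatter of two such steps

The size and direction of the step therefore depend on the core for this pair of cores. Going by these compounds alone, with only one pair on each core, this does not show which difference between the cores matters, nor how the change would behave on any other core.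

As far as these compounds go, it remains open which part of that core difference goes with the gap between the steps. Also open, from the compounds shown here alone, is whether the two cores would still part if a carboxylic acid replaced the methoxycarbonyl group, or if a longer chain stood on that nitrogen.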